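The source may hold more compounds than are shown below. What is called first, only, known or untested is meant among the compounds shown, and "the series" means these compounds.

The series is built on a shared core carrying a pendant six-membered aromatic ring. Compound 1 `COc1ccc(-c2cc(=S)c3ccc(C)cc3o2)cc1` and compound 2 `COc1ccc(-c2cc(=S)c3ccc(F)cc3o2)cc1` each place a methoxy on that pendant ring and differ only in the group on the core, methyl in one and fluorine in the other; compound 3 `COc1ccc(-c2cc(=S)c3ccccc3o2)cc1` keeps the methoxy and leaves the core unsubstituted. In an in vitro assay on BTI-TN-5B1-4 cells for inhibition of Amine oxidase [flavin-containing] A (Homo sapiens), tested at 100 uM (a higher number here means more inhibition at the concentration tested (going by the name of the read-out), a lower number less inhibition), compound 3 gives 40%. In this assay compound 1 gives "not active" (no number reported). In this assay compound 2 gives "not active" (no number reported), so no single number stands for it, and compound 1 is the one further entry that also carries no number. Compound 2 therefore stands without a value to rank, while compound 3 is the only one of the three with a reported figure.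

Compound 4 `Fc1ccc2c(=S)cc(-c3ccccc3)oc2c1` arises from compound 2 by hydrogen in place of methoxy on an aromatic carbon. Going by the values given here, no measured pair shows this change, so its size is unknown; given that compound 2 itself reports "not active" (no number reported), only a modest movement in this assay, upward or downward, is expected, and it may not clear the scatter. Compound 4 is estimated to give 15%, with a likely range from 0% to 40%.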

Compound 4, a percentage reported as inhibition, at one concentration (the size of the read-out at that concentration, not a potency): 40%
Estimate against measurement, compound 4: 25 percentage points below, within the range that was stated.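

In this assay, going by these compounds alone, compound 2 gives "not active" (no number reported), with no number, so no step to compound 4 can be read from this result. The compounds shown leave open how far swapping methoxy for hydrogen moves the inhibition when the core carries another group or none. Nothing measured here speaks to a cause for the result.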